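Replacing 6-methoxypyridazin-3-yl with 4-methoxyphenyl in compound 1

The compounds below may be only part of what the source reports. "The series", "measured", "known", "first", "only" and "open" are said of these compounds alone.

- compound 1 `COc1ccc(-n2nc(C(=O)N3CCOCC3)cc2-c2ccc(Cl)cc2)nn1` gives 83 nM 
- compound 2 `COc1ccc(-n2nc(C(=O)Nc3ccncc3)cc2-c2ccc(Cl)cc2)nn1` gives 110 nM 
- compound 3 `COc1ccc(NC(=O)c2cc(-c3ccc(Cl)cc3)n(-c3ccc(OC)nn3)n2)cc1` gives 400 nM 

Compound 1 has the lowest number of the three in a functional assay on a cell-free system (Platelet, plasma, Homo sapiens) for inhibition, read by turbidimetry, with a stated time of 3 min (on this read-out higher numbers stand for weaker inhibition and lower numbers for stronger inhibition), yet its nearest neighbour shows only a 1.3-fold higher number from compound 1 to compound 2 (0.12 log units; within the scatter), and its furthest shows a 4.8-fold higher number from compound 1 to compound 3 (0.68 log units; beyond the scatter).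

Compound 4 `COc1ccc(-n2nc(C(=O)N3CCOCC3)cc2-c2ccc(Cl)cc2)cc1` keeps the 4-chlorophenyl group and the (morpholin-4-yl)carbonyl group of compound 1, but has 4-methoxyphenyl in place of 6-methoxypyridazin-3-yl on an aromatic nitrogen.

For the measured compounds named here, no measured step touches that place. The closest guide is a swap elsewhere in the molecule, 4-methoxyphenyl in place of pyridin-4-yl on an amide-type nitrogen, which gave a 3.6-fold higher number from compound 2 to compound 3 (0.56 log units; beyond the scatter). That step carries over only loosely, so a modest move to a higher number in this assay is expected, with wide uncertainty. The estimate is a 2.0-fold higher number from compound 1 to compound 4 (0.31 log units; beyond the scatter), and this remains an expectation. For compound 4 the estimated value is 170 nM, with an expected range of 50 nM to 600 nM in this assay.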

Compound 4, half-maximal inhibitory concentration: 7.3 nM
Beside the measured number, compound 4's estimate is 23-fold (1.37 log units) above it; measured number below the stated range.
By their numbers in this assay, from the lowest: compound 4; then compounds 1 and 2 (each within the scatter of the next); then compound 3.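

For the compounds shown here, the group on the aromatic nitrogen, which no earlier step had touched, proved far more sensitive than the carbonyl end: in this assay the change gave an 11-fold lower number from compound 1 to compound 4 (1.06 log units; beyond the scatter) and so exceeds the largest earlier step, a 4.8-fold higher number from compound 1 to compound 3 (0.68 log units; beyond the scatter) (a swap on the carbonyl carbon). The heavy-atom count stays the same, while a ring with 2 hetero atoms gives way to a ring of carbon only, so a large step appears here without any change in the number of heavy atoms. Nothing available explains the size of this step.

As far as these compounds go, whether a pyridine ring carrying the same methoxy group would behave like 4-methoxyphenyl or like 6-methoxypyridazin-3-yl remains open. Also open, from the compounds shown here alone, are whether a chlorine or an ethoxy group could replace the methoxy group, and whether the same swap would lower the number for compound 2.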